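The source may report more compounds than this note shows. Statements on the series, on what has been measured and on what is new or still open speak of the compounds shown alone.

Measured in a functional assay on MCF7 cells (Homo sapiens) for cytotoxicity, read by MTT assay, with a stated time of 48 h; on this read-out higher numbers stand for weaker inhibition and lower numbers for stronger inhibition:
- compound 1 `COc1cc(C#N)ccc1OCc1nnc(-c2ccc(Cl)cc2)o1`: 21500 nM
- compound 2 `N#Cc1ccc(OCc2nnc(-c3ccccc3)o2)cc1F`: > 50000 nM

Compound 2 has no number on this read-out. Compound 2 gives only > 50000 nM, which is a limit of this assay and not a measured half-maximal inhibitory concentration. Any step away from compound 2 is therefore itself uncertain in size.

The next compound is compound 3 `N#Cc1ccc(OCc2nnc(-c3ccc(Cl)cc3)o2)cc1F`. It keeps the frame of compound 2 and takes chloro in place of hydrogen on an aromatic carbon, para to a large group, so that phenyl becomes 4-chlorophenyl: chloro in place of hydrogen on an aromatic carbon.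

Going by the values given here, no measured pair isolates this change, so any expectation rests on thin ground. Compound 1 also carries the 4-chlorophenyl group and differs from compound 3 elsewhere. In this assay compound 1 gives 21500 nM. A reading inside the measurable range is therefore expected, though another limit remains quite possible. The expected change is modest and toward stronger inhibition, estimated as an at least 1.7-fold lower number from compound 2 to compound 3 (0.25 log units; that floor lies within the scatter). For compound 3 the estimated value is 28000 nM, with an expected range of 12000 nM to 50000 nM.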

Compound 3, half-maximal inhibitory concentration: 48300 nM
Beside the measured number, compound 3's estimate is 1.7-fold (0.24 log units) below it; the range from low to high includes it.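

In this assay, chloro in place of hydrogen on an aromatic carbon, para to a large group, turning phenyl into 4-chlorophenyl, gives an at least 1.0-fold lower number from compound 2 to compound 3 (0.01 log units; that floor lies within the scatter). Going by these compounds alone, this is the first read of this change on the frame of compound 2, and compound 3 gives 48300 nM, an actual number on that frame, though the printed step does not by itself establish any gain in inhibition. The step is only a floor, and its true size stays unknown because compound 2 has a limit and not a number: the limit of > 50000 nM in this assay, at which 1 of the 3 values shown sits.

From the compounds shown here alone, compound 1 shares the 4-chlorophenyl group with compound 3 but differs from it in more than one place, so that pair does not show what the rest of the frame contributes, and whether the chloro change would exceed the usual scatter on a frame with a measurable parent remains open. Also open, going by these compounds, is how this same position responds to a group other than chloro, such as an amine, a carboxylic acid or a longer chain like butyl, in place of that hydrogen.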